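The compounds below may be only part of what the source reports. "The series", "measured", "known", "first", "only" and "open" are said of these compounds alone.

Working notes on the series. Compound 1 `Cc1ccc(S(=O)(=O)N[C@H]2CCC(=O)[C@@H]2C/C=C\CCCC(=O)O)cc1` gives 670 nM in a functional assay (plasma) for inhibition, with Homo sapiens as the target; on this read-out lower numbers stand for stronger inhibition and higher numbers for weaker inhibition. Compound 3 `Cc1ccc(S(=O)(=O)N[C@@H]2CC[C@@H](O)[C@H]2C/C=C\CCCC(=O)O)cc1` shares the tolyl sulfonamide but carries the other core; in this assay compound 3 gives 5800 nM. How the core of compound 1 and the core of compound 3 differ is not broken down here; of the three measured numbers, compound 1 has the lowest, with compound 3 nearest and compound 2 furthest, both beyond the scatter.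

Compound 2 `O=C(O)CCC/C=C\C[C@@H]1[C@H](O)CC[C@H]1NS(=O)(=O)c1ccc(F)cc1` is the fluoro analogue of compound 3 and in this assay compound 2 gives 6000 nM. The change fluoro in place of methyl on an aromatic carbon made a step of a 1.0-fold higher number from compound 3 to compound 2 (0.01 log units; within the scatter).

Compound 4 `O=C(O)CCC/C=C\C[C@H]1C(=O)CC[C@@H]1NS(=O)(=O)c1ccc(F)cc1` is the same change applied to compound 1: fluoro in place of methyl on an aromatic carbon. The place is identical in both pairs, so this is taken as the same change. The step of a 1.0-fold higher number from compound 3 to compound 2 (0.01 log units; within the scatter) sat within the scatter. The matching step for compound 4 is expected to be about the same size, namely a 1.0-fold higher number from compound 1 to compound 4 (0.02 log units; within the scatter). Compound 4 is therefore estimated at 700 nM, with a likely range from 350 nM to 1400 nM.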

Compound 4, half-maximal inhibitory concentration: 500 nM
For compound 4 the middle estimate is 1.4-fold (0.15 log units) above the measured one; low and high end bracket the measured number.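

In this assay the new step, a 1.3-fold lower number from compound 1 to compound 4 (0.13 log units; within the scatter), lies within the scatter, and it does not differ from the earlier step on the other core: the same change on two cores in this assay, a 1.0-fold higher number (0.01 log units; within the scatter) from compound 3 to compound 2 and a 1.3-fold lower number (0.13 log units; within the scatter) from compound 1 to compound 4, 1.4-fold (0.14 log units) apart, within the scatter of two such steps. The change from 4-methylphenyl to 4-fluorophenyl therefore carried over between the core of compound 3 and the core of compound 1, with no readable effect on the number on either core. For the compounds shown here, this rests on only two pairs and one change, so it does not show that the same would hold on any further core, that other groups at this place would behave alike, or that an effect smaller than the scatter is absent.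

The compounds shown leave open whether methoxy, chloro or a nitrile on the same aromatic carbon would also leave the number within the scatter. Also open, on these data alone, is how the number would respond to an amide in place of the carboxylic acid, or to a shorter chain carrying it.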